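A Pyridine Ring in Place of Phenyl

The compounds below may be only part of what the source reports. "The series", "measured", "known", "first", "only" and "open" are said of these compounds alone.

Compound 1 (`Oc1ccc(-c2cc(-c3ccccc3)cc(-c3cccnc3)n2)cc1`): 2200 nM
Compound 2 (`Oc1cccc(-c2cc(-c3ccccc3)nc(-c3ccccc3)c2)c1`): 19500 nM

In a functional assay on MDA-MB-231 cells (Homo sapiens) for cytotoxicity, read by ELISA, with a stated time of 2 days (a higher number here means a weaker inhibitor, a lower number a stronger inhibitor), compound 2 has the higher of the two numbers (19500 nM), so it is the weaker inhibitor, and the gap lies beyond the scatter. Compound 3 (`Oc1cccc(-c2cc(-c3ccccc3)nc(-c3ccccn3)c2)c1`) carries pyridin-2-yl in place of phenyl on an aromatic carbon. Within the data shown here, no measured pair shows this change alone. Compound 1 (2200 nM) differs from compound 2 in more than one place, so it offers only a weak hint toward a lower number. A moderate drop is expected, estimated as a 2.8-fold lower number from compound 2 to compound 3 (0.44 log units; beyond the scatter) here. For compound 3 the estimate is 7000 nM, with an expected range from 2000 nM to 22000 nM.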

Compound 3, half-maximal inhibitory concentration: 18700 nM
Estimate against measurement, compound 3: 2.7-fold (0.43 log units) below; the measured number falls inside the stated range.
By their numbers in this assay, from the lowest: compound 1; then compounds 3 and 2 (each within the scatter of the next).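

In this assay, among these compounds, the step of a 1.0-fold lower number from compound 2 to compound 3 (0.02 log units; within the scatter) comes with pyridin-2-yl in place of phenyl, the first change at this position that can be read alone. On this aromatic carbon, next to the ring nitrogen, the swap adds a ring nitrogen and a hydrogen-bond acceptor, yet the two numbers stay within the scatter of each other. No measurement at hand offers an explanation for this. From the compounds shown here alone, whether an amine or a carboxylic acid on the same carbon would shift the number remains open. So does the effect of a methoxy group replacing the hydroxyl of the 3-hydroxyphenyl group.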